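This account rests on a few compounds, and the source may have more. Where it says the series, first, only, none or still open, it means among the compounds named here.

Measured so far:
compound 1, `Brc1cn2ccnc2c(-c2ccc3ncn(C4CCCCC4)c3c2)n1`: 26.8%
compound 2, `Brc1ccc(-c2cn3ccnc3c(-c3ccc4ncn(C5CCCCC5)c4c3)n2)cc1`: 60.7%

In a functional assay on SR cells (Homo sapiens) for inhibition, read by sulforhodamine B assay, with a stated time of 48 h, tested at 10 uM (a higher number here means more inhibition at the concentration tested (going by the name of the read-out), a lower number less inhibition), compound 1 gives 26.8% and compound 2 gives 60.7%. Compound 1 stands lowest of the two numbers; its nearest neighbour is compound 2, separated by a number 33.9 percentage points higher from compound 1 to compound 2 (beyond the scatter), a step beyond the scatter.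

Compound 3, `FC(F)(F)c1cccc(-c2cn3ccnc3c(-c3ccc4ncn(C5CCCCC5)c4c3)n2)c1`, has not been measured in this assay. It differs from compound 1 by 3-(trifluoromethyl)phenyl in place of bromo on an aromatic carbon.

For the measured compounds named here, the one measured step that bears on this change is a number 33.9 percentage points higher from compound 1 to compound 2 (beyond the scatter), which also puts a six-membered aromatic ring of carbon only in place of bromo on an aromatic carbon of the shared core. By analogy a rise of similar size is expected for compound 3, though the group entering here carries a trifluoromethyl where compound 2 carries a bromo, so the match is not exact and the range is set wide. The step this estimate means is a number 28.2 percentage points higher from compound 1 to compound 3 (beyond the scatter). For compound 3 the expected value in this assay is 55%, with a range from 35% to 75%.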

Compound 3, a percentage reported as inhibition, at one concentration (the size of the read-out at that concentration, not a potency): 15.6%
The estimate for compound 3 lay 39.4 percentage points above the measured number; the whole stated range lies above it.
By their numbers in this assay, from the lowest: compound 3; then compound 1; then compound 2.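

Working notes on the position bearing the bromo in compound 1, read in this assay: adding a six-membered aromatic ring of carbon only does not by itself raise the number, since 3-(trifluoromethyl)phenyl gives a number 11.2 percentage points lower from compound 1 to compound 3 (beyond the scatter), against a number 33.9 percentage points higher from compound 1 to compound 2 (beyond the scatter) for 4-bromophenyl. Exchanging one of these substituted rings for the other gives a number 45.1 percentage points lower from compound 2 to compound 3 (beyond the scatter), so at this position the result depends on what the entering ring carries and where it carries it, not on the presence of the ring alone. No measured information on the compounds accounts for this difference between the two groups.

The substituent and its place on the ring change together between compound 2 and compound 3, so the shown compounds do not separate the two; 3-bromophenyl and 4-(trifluoromethyl)phenyl would do so. Also open, going by these compounds, is how the unsubstituted phenyl, or a phenyl ring bearing an amine or a carboxylic acid, would read at this position on the shared core.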